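The source may hold more compounds than are shown below. What is called first, only, known or untested is meant among the compounds shown, and "the series" means these compounds.

Compound 1 `CCOC(=O)c1cc(=O)c2cc(CSC(=S)N(C)c3ccccc3)ccc2o1` carries a methyl(phenyl)amino group on a thiocarbonyl carbon whose other neighbour is sulfur. In a functional assay on SW480 cells (Homo sapiens) for antiproliferative activity, read by MTT assay, with a stated time of 72 h (a lower number here means a stronger inhibitor, a higher number a weaker inhibitor), compound 1 gives only a limit, > 25000 nM. Compound 2 `O=c1c(CSC(=S)N2CCN(C(c3ccc(F)cc3)c3ccc(F)cc3)CC2)coc2ccccc12` likewise reaches only a limit in this assay, > 40000 nM. Compound 3 `O=c1cc(CSC(=S)N2CCCC2)oc2cc(Cl)ccc12` also stops at a limit in this assay, > 25000 nM. Among the compounds with values here, two of the three recorded values therefore sit at the limit of > 25000 nM in this assay, at which 2 of the 3 values shown sit, and the third at the limit of > 40000 nM in this assay, at which 1 of the 3 values shown sits, so no compound measured so far has given a number, and no step between measured compounds can be read.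

Compound 4 `CCOC(=O)c1cc(=O)c2cc(CSC(=S)N3CCOCC3)ccc2o1` is the next compound to be tested. It differs from compound 1 in one place: morpholin-4-yl in place of methyl(phenyl)amino on a thiocarbonyl carbon. Within the data shown here, with every recorded value a limit, there is no measured step to lean on, and the expectation for this change is no movement beyond the scatter. The expected step is a step that the limit leaves unreadable from compound 1 to compound 4, and compound 4 is expected most likely to report a limit again. Compound 4 is estimated at 40000 nM in this assay, with a range from 15000 nM to 100000 nM.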

Compound 4, half-maximal inhibitory concentration: > 25000 nM
Compound 4 ended at the assay's limit; the forecaster's own chance of this, stated with the estimate: 85%; the middle value does not contradict the limit.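

In this assay compound 4 gives > 25000 nM, which is a limit. Within the data shown here, compound 1 also gave only a limit, so no step between compound 1 and compound 4 can be read. The compounds shown leave open whether morpholin-4-yl and methyl(phenyl)amino differ in activity at all.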